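From cyano to amino on the shared core

A few compounds are considered here, and "the series" means these few. Any claim that something is new, unique, unknown or untested is made for them only; others in the source may bear on it.

Values in a functional assay on the whole organism with Mus musculus as the target, with a stated time of 45 min (a lower number here means that less compound is needed, a higher number that more compound is needed for the effect), each one a limit:
compound 1 `COc1cc2c(cc1OC)C(c1ccc(Br)cc1)=NNC(=O)C2` gives > 150 umol/kg
compound 2 `COc1cc2c(cc1OC)C(c1ccc(C#N)cc1)=NNC(=O)C2` gives > 150 umol/kg
compound 3 `COc1cc2c(cc1OC)C(c1cccc([N+](=O)[O-])c1)=NNC(=O)C2` gives > 150 umol/kg

Compound 2 stands at > 150 umol/kg, which is a limit and not a number. Among the measured compounds shown here, the series so far shows the limit of > 150 umol/kg in this assay, at which 3 of the 3 values shown sit, and so offers no numeric anchor. Compound 4 `COc1cc2c(cc1OC)C(c1ccc(N)cc1)=NNC(=O)C2` carries amino in place of cyano on an aromatic carbon, para to a large group amino in place of cyano on an aromatic carbon on the same core. For the measured compounds named here, one measured step bears on this site, namely a step that the two limits leave unreadable from compound 1 to compound 2 for cyano in place of bromo on an aromatic carbon, and it gives no size to carry over. Going by the values given here, no measured compound carries amino, so the expectation in this assay is weak. A move toward a lower dose is expected, though a further limit would be no surprise. The expected change, as a rough estimate, is an at least 1.6-fold lower number from compound 2 to compound 4 (0.22 log units; that floor lies within the scatter) in this series. For compound 4 the estimate is 90 umol/kg, with an expected range of 25 umol/kg to 250 umol/kg in this assay.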

Compound 4, dose for half-maximal effect: 22.6 umol/kg
Compound 4: the middle estimate sits 4.0-fold (0.60 log units) above what was measured; the measured number lies below the stated range.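

Within this assay, compound 4 is the first compound in the series to give a number rather than a limit, which shows that the group at this place on the aromatic ring can move the dose into a readable range. Amino in place of cyano gives an at least 6.6-fold lower number from compound 2 to compound 4 (0.82 log units; beyond the scatter), and amino in place of bromo gives an at least 6.6-fold lower number from compound 1 to compound 4 (0.82 log units; beyond the scatter). Both steps are floors and not full sizes, and the rest of the series still offers only a limit as its reference: the limit of > 150 umol/kg in this assay, at which 3 of the 4 values shown sit.

As far as these compounds go, it stays open whether amino is unique here or whether a hydroxyl, dimethylamino or acetylamino group at the same place would give a similar dose. Also open, from the compounds shown here alone, is whether the step holds with groups other than the two methoxy groups on the shared core.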